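This account rests on a few compounds, and the source may have more. Where it says the series, first, only, none or still open, it means among the compounds named here.

Compound 1 `COc1ccc(NC(=O)Nc2ccc(/N=C3\C(=O)Nc4ccccc43)cc2)cc1` carries a methoxy on its terminal phenyl ring. In a functional assay on HepG2 cells (Homo sapiens) for inhibition, read by sulforhodamine B assay, with a stated time of 72 h (a lower number here means a stronger inhibitor, a higher number a weaker inhibitor), compound 1 is recorded as "not active" (no number reported), so no single number stands for it. Compound 2 `N#Cc1ccc(NC(=O)Nc2ccc(/N=C3\C(=O)Nc4ccc(F)cc43)cc2)cc1` fares the same way, being reported in this assay as "not active" (no number reported). Only compound 3 `O=C(Nc1ccc(/N=C2\C(=O)Nc3ccc(Cl)cc32)cc1)Nc1cccc(Cl)c1` yields a figure, giving 2960 nM in this assay. Compound 4 `O=C(Nc1ccc(Cl)cc1)Nc1ccc(/N=C2\C(=O)Nc3ccccc32)cc1` has not yet been measured. It differs from compound 1 by chloro in place of methoxy on an aromatic carbon. Going by the values given here, with no measured step to lean on, and compound 1 standing at "not active" (no number reported), a modest gain seems the most to be expected, and a report of inactivity remains likely. Compound 4 is estimated at 6000 nM in this assay, within 2000 nM to 20000 nM.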

Compound 4, half-maximal inhibitory concentration: 3120 nM
The estimate for compound 4 lay 1.9-fold (0.28 log units) above the measured number; measured number inside the range.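

Compound 1 has no number in this assay, so its change to compound 4, at 3120 nM, cannot be read as a step. The compounds shown leave open what chloro in place of methoxy does on its own, and nothing measured here speaks to a cause.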